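Ethoxycarbonyl to methylcarbamoyl: working notes on the series

The source may report more compounds than this note shows. Statements on the series, on what has been measured and on what is new or still open speak of the compounds shown alone.

Of the compounds shown here, two are measured so far. In a functional assay on A2780 cells (Homo sapiens) for inhibition (a higher number here means a weaker inhibitor, a lower number a stronger inhibitor), compound 1 `CCNC(=O)c1noc(-c2cc(C(C)C)c(O)cc2O)c1-c1cc(CN2CCCC2)no1` gives 55 nM, and compound 2 `CCNC(=O)c1noc(-c2cc(C(C)C)c(O)cc2O)c1-c1cc(C(=O)OCC)no1` gives 9000 nM, the higher of the two numbers and so the weaker inhibitor.

Compound 3 `CCNC(=O)c1noc(-c2cc(C(C)C)c(O)cc2O)c1-c1cc(C(=O)NC)no1` carries methylamino in place of ethoxy on a carbonyl carbon. Within the data shown here, the only measured step bearing on this change is a 160-fold higher number from compound 1 to compound 2 (2.21 log units; beyond the scatter), a large step in which ethoxycarbonyl replaced (pyrrolidin-1-yl)methyl. It shows that the group at this place can shift this assay strongly, but no amide has been measured, so its size is not a direct guide. A lower number than that of compound 2 is expected, though by a smaller margin than in the measured step. The expected step is a 6.0-fold lower number from compound 2 to compound 3 (0.78 log units; beyond the scatter). The estimate for compound 3 is 1500 nM, with an expected range of 250 nM to 9000 nM.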

Compound 3, half-maximal inhibitory concentration: 100 nM
Compound 3: middle estimate off by 15-fold (1.18 log units), on the high side; measured number outside the range, below it.
By their numbers in this assay, from the lowest: compounds 1 and 3 (each within the scatter of the next); then compound 2.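

In this assay the step of a 90-fold lower number from compound 2 to compound 3 (1.95 log units; beyond the scatter) shows that exchanging ethoxy for methylamino on a carbonyl carbon is enough on its own to produce a large change, with the rest of the structure held the same. The step of a 1.8-fold higher number from compound 1 to compound 3 (0.26 log units; within the scatter) adds that this read-out does not separate methylcarbamoyl from (pyrrolidin-1-yl)methyl, so a low number at this place is not tied to (pyrrolidin-1-yl)methyl alone. Nothing in hand explains the wide gap between ethoxycarbonyl and methylcarbamoyl.

From the compounds shown here alone, whether the amide hydrogen matters remains open, and dimethylcarbamoyl, which lacks it, would test this directly. Going by these compounds, how far the amide tolerates change also remains open, and unsubstituted carbamoyl, ethylcarbamoyl and the carboxylic acid would each extend the comparison at this place.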